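The source may hold more compounds than are shown below. What is called first, only, known or untested is meant among the compounds shown, and "the series" means these compounds.

Compound 1 `CCN(CC)c1cc2[nH]c(C3CCCCC3)nc2cc1NC(=O)OCC(F)(F)F`: > 100 ug/mL
Compound 2 `CN(C)c1cc2[nH]c(C3CCCCC3)nc2cc1NC(=O)OCC(F)(F)F`: > 100 ug/mL
Compound 3 `CCN(CC)c1cc2[nH]c(C3CCCCC3)nc2cc1NC(=O)c1ccc(OC(F)(F)F)cc1`: > 100 ug/mL

In an ADME assay on Vero cells (Chlorocebus sabaeus) for cytotoxicity, read by resazurin assay, with a stated time of 3 days (on this read-out higher numbers stand for weaker inhibition and lower numbers for stronger inhibition), compound 2 gives > 100 ug/mL, which is a limit and not a number. Going by the values given here, the other two results are limits as well, so the only guide is the limit of > 100 ug/mL in this assay, at which 3 of the 3 values shown sit. Compound 4 `CCCCCC(=O)Nc1cc2nc(C3CCCCC3)[nH]c2cc1N(C)C` differs from compound 2 on a carbonyl carbon: pentyl in place of 2,2,2-trifluoroethoxy on a carbonyl carbon. The closest measured change, at that same kind of carbon, is a step that the two limits leave unreadable from compound 1 to compound 3. The other measured change is a step that the two limits leave unreadable from compound 1 to compound 2. Neither gives a size to carry over, and compound 3 sits at the limit of > 100 ug/mL. No step beyond the scatter is therefore expected in this assay, and the expected change is a number no higher from compound 2 to compound 4 (the limit leaves the size open). For compound 4 the estimated value is 100 ug/mL, with an expected range of 40 ug/mL to 200 ug/mL.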

Compound 4, half-maximal inhibitory concentration: > 100 ug/mL
Compound 4 gave a limit, no number (the forecaster's own chance of this, stated with the estimate: 70%); the middle value lies on the limit itself.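

Compound 2 and compound 4 both give limits, not numbers, in this assay, so no step can be read between them. The compounds shown leave open where any of their true values lies, as every result is the same limit: the limit of > 100 ug/mL in this assay, at which 4 of the 4 values shown sit.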